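Aryl Swap on the Piperazine: Dichlorophenyl Analog Expected

The compounds below may be only part of what the source reports. "The series", "measured", "known", "first", "only" and "open" are said of these compounds alone.

Compound 1 `CCOc1ccccc1N1CCN(CC(O)CN2C(=O)NC(C)(c3ccc(F)cc3)C2=O)CC1`: 81 nM
Compound 2 `CC1(c2ccc(F)cc2)NC(=O)N(CC(O)CN2CCN(c3ccccc3C#N)CC2)C1=O`: 343 nM

In a functional assay on HEK293 cells for antagonist activity at 5-hydroxytryptamine receptor 7 (Homo sapiens), read by HTRF and cAMP accumulation, with a stated time of 15 min (a higher number here means a weaker inhibitor, a lower number a stronger inhibitor), compound 2 gives 343 nM, the higher of the two numbers. Its nearest neighbour, compound 1, gives 81 nM. Going by the values given here, the one measured step, a 4.2-fold higher number from compound 1 to compound 2 (0.63 log units; beyond the scatter), lies beyond the scatter. Compound 3 `CC1(c2ccc(F)cc2)NC(=O)N(CC(O)CN2CCN(c3ccc(Cl)c(Cl)c3)CC2)C1=O` differs from compound 2 by 3,4-dichlorophenyl in place of 2-cyanophenyl on an amine nitrogen in a ring. Among the compounds with values here, no measured step exchanges a cyanophenyl for a dichlorophenyl, so that single step only shows that a change at this ring can move the number beyond the scatter, in either direction. Compound 3 is therefore expected at about 250 nM, with a range of 60 nM to 1000 nM. This estimate corresponds to an expected step of a 1.4-fold lower number from compound 2 to compound 3 (0.14 log units; within the scatter) in this assay.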

Compound 3, half-maximal inhibitory concentration: 24000 nM
Beside the measured number, compound 3's estimate is 96-fold (1.98 log units) below it; the measured number lies above the stated range.
By their numbers in this assay, from the lowest: compound 1; then compound 2; then compound 3.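

In this assay the swap to 3,4-dichlorophenyl gives a 70-fold higher number from compound 2 to compound 3 (1.84 log units; beyond the scatter) and also a 300-fold higher number from compound 1 to compound 3 (2.47 log units; beyond the scatter) and both steps are far larger than the modest one between the two earlier compounds. The aryl group on this amine nitrogen in a ring can therefore move the number over a much wider span than 2-ethoxyphenyl and 2-cyanophenyl alone showed. Nothing available bears on the reason for this. Still open, from the compounds shown here alone, is whether the rise goes with the chlorines themselves or with where they sit on the ring; a 2-chlorophenyl or a plain phenyl group at this nitrogen would separate the two.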